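Swapping the group on the sulfur chain of compound 1

This account rests on a few compounds, and the source may have more. Where it says the series, first, only, none or still open, it means among the compounds named here.

- Compound 1 (`Cc1cc(N2CC[C@@H](C)[C@@H](N(C)c3ncnc4[nH]ccc34)C2)n2nc(SCc3nc4ccccc4[nH]3)nc2n1`) gives > 100000 nM as its reading
- Compound 2 (`Cc1nc2nc(SCc3ccc(Cl)cc3)nn2c(N2CC[C@@H](C)[C@@H](N(C)c3ncnc4[nH]ccc34)C2)c1C`) gives > 100000 nM as its reading
- Compound 3 (`CCCCCc1c(C)nc2nc(SCc3ccc(Cl)cc3)nn2c1N1CC[C@@H](C)[C@@H](N(C)c2ncnc3[nH]ccc23)C1`) gives 32300 nM as its reading

In a functional assay on BGC-823 cells (Homo sapiens) for inhibition, read by MTT assay, with a stated time of 72 h (a lower number here means a stronger inhibitor, a higher number a weaker inhibitor), compound 1 gives > 100000 nM and this is a limit of the assay, not a number. For compound 1 the results show the limit of > 100000 nM in this assay, at which 2 of the 3 values shown sit, and compound 2 is the other such case. Only compound 3 has a true number.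

Compound 4 (`Cc1cc(N2CC[C@@H](C)[C@@H](N(C)c3ncnc4[nH]ccc34)C2)n2nc(SCc3ccc(F)c(Cl)c3)nc2n1`) differs from compound 1 in one place (3-chloro-4-fluorophenyl in place of 1H-benzimidazol-2-yl on a saturated chain carbon bound to a sulfur) with 3-chloro-4-fluorophenyl in place of 1H-benzimidazol-2-yl on a saturated chain carbon bound to a sulfur. Among the compounds with values here, no measured step tests this exchange directly. Within the data shown here, the one measured step is an at least 3.0-fold lower number from compound 2 to compound 3 (0.49 log units; beyond the scatter) and it came from butyl in place of hydrogen on a saturated chain carbon bound to an aromatic carbon, which is a different place, so it offers only a loose guide to size. Compound 2 also carries a chlorinated benzyl group on its sulfur, and its > 100000 nM is likewise a limit.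

A modest move at most is therefore expected in this assay and any move should be toward a lower number. The expected change is an at least 1.4-fold lower number from compound 1 to compound 4 (0.15 log units; that floor lies within the scatter) as an estimate. For compound 4 the estimated value is 70000 nM with an expected range from 25000 nM to 100000 nM in this assay.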

Compound 4, half-maximal inhibitory concentration: 98900 nM
Compound 4: the middle estimate sits 1.4-fold (0.15 log units) below what was measured; measured number inside the range.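

Putting 3-chloro-4-fluorophenyl in place of 1H-benzimidazol-2-yl on a saturated chain carbon bound to a sulfur gives a number no higher from compound 1 to compound 4 (the limit leaves the size open), the only direct test of this position among the compounds shown in this assay. Compound 4 gives 98900 nM, a true number, so 1H-benzimidazol-2-yl and the hydrogen-bond donor it carries can be exchanged on this core with a number still being read. How much the exchange changes the reading cannot be told, because compound 1 has only a limit and not a number: the limit of > 100000 nM in this assay, at which 2 of the 4 values shown sit.

The compounds shown leave open whether another group at this position, such as a benzyl group carrying an amine or a carboxylic acid, or a longer chain on the sulfur, would give a clearly lower number than compound 4. They also leave open whether the butyl exchange behind an at least 3.0-fold lower number from compound 2 to compound 3 (0.49 log units; beyond the scatter) would lower the number in the same way if it were made on compound 4.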